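Swapping an ethoxy for a fluorophenoxy on a biaryl acid

The source may hold more compounds than are shown below. What is called first, only, known or untested is meant among the compounds shown, and "the series" means these compounds.

In a functional assay on isolated protein for agonist activity at Free fatty acid receptor 1 (Homo sapiens), read by HTRF and inositol phosphate accumulation, with a stated time of 60 min (a higher number here means that more compound is needed for the effect, a lower number that less compound is needed), compound 1 `CCOc1ccc(Cl)c(-c2ccc(OCCCC(=O)O)cc2)c1` gives 1130 nM, the lowest of the three numbers measured. Compound 2 `CCOc1ccc(F)c(-c2ccc(OCCCC(=O)O)cc2)c1` gives 3190 nM in this assay, and compound 3 `COc1cccc(Oc2cccc(-c3ccc(OCCCC(=O)O)cc3)c2)c1` gives 6310 nM. Going by the values given here, the only single-point comparison among them is a 2.8-fold higher number from compound 1 to compound 2 (0.45 log units; beyond the scatter), so compound 1 sits at the strong end, with compound 3 furthest from it.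

Compound 4 `O=C(O)CCCOc1ccc(-c2cc(Oc3cccc(F)c3)ccc2Cl)cc1` is compound 1 with 3-fluorophenyl in place of ethyl on an oxygen on an aromatic ring. Among the compounds with values here, no measured pair captures this change directly. Within the data shown here, the one measured step concerns a halogen swap on an aromatic carbon, not the group on the oxygen, so it gives little guidance. Compound 3, which carries an aryl ether in place of a small alkyl ether, shows a higher number than compound 1, but it differs from compound 1 in more than one place, so only the two values themselves can be compared. On that slender basis, a rise beyond the scatter is expected, a 2.5-fold higher number from compound 1 to compound 4 (0.39 log units; beyond the scatter). Compound 4 is therefore estimated at 2800 nM, with a likely range from 700 nM to 11000 nM.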

Compound 4, half-maximal effective concentration: 3350 nM
For compound 4 the middle estimate is 1.2-fold (0.08 log units) below the measured one; the measured number falls inside the stated range.
By their numbers in this assay, from the lowest: compound 1; then compounds 2, 4 and 3 (each within the scatter of the next).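

On the oxygen of the core of compound 1, the change from ethyl to 3-fluorophenyl gives a 3.0-fold higher number from compound 1 to compound 4 (0.47 log units; beyond the scatter) in this assay. Going by these compounds alone, this is the first direct reading of a change at this place, as the earlier step dealt only with a halogen on an aromatic carbon. The step is modest even though the entering group is much larger and brings a six-membered aromatic ring, and no supporting measurement explains the rise.

The compounds shown cannot separate the effect of the ring from that of its fluorine, and a plain phenyl on the same oxygen would be the direct test. On these data alone, it also remains open how a benzyl or a cyclohexyl would behave here, or whether a fluoro in place of the chloro would shift the number as it does with the ethoxy group present.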